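Pyridin-2-yl to 5-methyl-1,2-oxazol-3-yl on the amide nitrogen

The source may hold more compounds than are shown below. What is called first, only, known or untested is meant among the compounds shown, and "the series" means these compounds.

Three compounds share one core and differ only in the ring on the amide nitrogen. Compound 1 `O=C(COc1ccc(/C=C2\SC(=O)NC2=O)cc1)Nc1nc2ccccc2s1` gives 25100 nM in a functional assay on MCF7 cells (Homo sapiens) for cytotoxicity, read by sulforhodamine B assay, with a stated time of 48 h; a lower number here means a stronger inhibitor of growth, a higher number a weaker inhibitor of growth. Compound 2 `O=C(COc1ccc(/C=C2\SC(=O)NC2=O)cc1)Nc1ncc([N+](=O)[O-])s1` gives only a limit of the assay, < 100000 nM. Compound 3 `O=C(COc1ccc(/C=C2\SC(=O)NC2=O)cc1)Nc1ccccn1` gives 29500 nM, which is the highest of the two real numbers, with compound 1 nearest at a 1.2-fold higher number from compound 1 to compound 3 (0.07 log units; within the scatter). The steps a step that the limit leaves unreadable from compound 1 to compound 2 and a step that the limit leaves unreadable from compound 2 to compound 3 cannot be sized, since the value of compound 2 is a limit (the limit of < 100000 nM in this assay, at which 1 of the 3 values shown sits).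

Compound 4 `Cc1cc(NC(=O)COc2ccc(/C=C3\SC(=O)NC3=O)cc2)no1` is not yet measured; it differs from compound 3 by 5-methyl-1,2-oxazol-3-yl in place of pyridin-2-yl on an amide-type nitrogen. Among the measured compounds shown here, no measured step covers this exact exchange. For the measured compounds named here, the only readable step, from compound 1 to compound 3, shows that replacing one ring on the amide nitrogen by another left the number within the scatter. On that basis the step from compound 3 to compound 4 is expected to be small, a 1.0-fold higher number from compound 3 to compound 4 (0.01 log units; within the scatter), with no clear direction. Compound 4 is therefore estimated at 30000 nM, between 12000 nM and 80000 nM.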

Compound 4, concentration for 50% growth inhibition: 39800 nM
Compound 4: the middle estimate sits 1.3-fold (0.12 log units) below what was measured; the measured number falls inside the stated range.
By their numbers in this assay, from the lowest: compounds 1, 3 and 4 (each within the scatter of the next).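

In this assay, 5-methyl-1,2-oxazol-3-yl in place of pyridin-2-yl on the amide nitrogen gives a 1.3-fold higher number from compound 3 to compound 4 (0.13 log units; within the scatter), and the same group in place of 1,3-benzothiazol-2-yl gives a 1.6-fold higher number from compound 1 to compound 4 (0.20 log units; within the scatter). This position thus now takes a five-membered aromatic ring with 2 hetero atoms as well as the six-membered ring of compound 3, and no readable step among compound 1, compound 3 and compound 4 leaves the scatter. The steps to compound 4 and compound 3 from compound 2 cannot be read, since its value is a limit: the limit of < 100000 nM in this assay, at which 1 of the 4 values shown sits.

All four compounds carry an aromatic ring on this nitrogen. On these data alone, whether an open alkyl chain, a phenyl ring bearing a carboxylic acid or a ring with an amine would give a number beyond the scatter remains open.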